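The source may report more compounds than this note shows. Statements on the series, on what has been measured and on what is new or still open speak of the compounds shown alone.

The measured compounds:
- compound 1, `O=C(NCC1CCCCC1)c1cccc(/C=C2\CC(=O)N(c3ccccc3)C2=O)c1`: > 100000 nM
- compound 2, `CCCCCN1C(=O)C/C(=C\c2cccc(C(=O)Nc3cccc(F)c3)c2)C1=O`: > 100000 nM
- compound 3, `CCc1cccc(NC(=O)c2cccc(/C=C3\CC(=O)N(Cc4ccccc4)C3=O)c2)c1`: 80600 nM

These three share a core and differ in the groups hung on it. In an ADME assay on HCT-116 cells (Homo sapiens) for cytotoxicity, read by MTT assay, with a stated time of 72 h (a higher number here means a weaker inhibitor, a lower number a stronger inhibitor), compound 1 gives > 100000 nM, which is a limit of the assay rather than a number. Compound 2 likewise gives only a limit in this assay, > 100000 nM. Among the measured compounds shown here, compound 3 is the one with a number, 80600 nM. So compound 1 stands where most of these values sit: at the limit of > 100000 nM in this assay, at which 2 of the 3 values shown sit.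

Compound 4, `Cc1cccc(NC(=O)c2cccc(/C=C3\CC(=O)N(c4ccccc4)C3=O)c2)c1`, has not been measured. It differs from compound 1 in one place:
3-methylphenyl in place of cyclohexylmethyl on an amide-type nitrogen

For the measured compounds named here, no step between two measured compounds is available to guide this change. Given that compound 1 and compound 2 both rest at the limit and compound 3 lands near it, the expectation for this assay is a step of no real size, none beyond the scatter, with compound 4 most likely also returning only a limit. Compound 4 is therefore estimated at 100000 nM, with a range from 50000 nM to 250000 nM. The step this estimate implies, a number no higher from compound 1 to compound 4 (the limit leaves the size open), is expected to be essentially flat.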

Compound 4, half-maximal inhibitory concentration: > 100000 nM
Compound 4: a limit, no number; the forecaster's own chance of this, stated with the estimate: 65%; the middle value lies on the limit itself.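

Among the compounds shown here, compound 1 and compound 4 both return only a limit in this assay, not a number, so no step between them can be read. Both rest at the same point: the limit of > 100000 nM in this assay, at which 3 of the 4 values shown sit.

The compounds shown leave open whether 3-methylphenyl in place of cyclohexylmethyl on an amide-type nitrogen changes the result at all.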